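Replacing the pentyl chain of compound 1 with ethylamino

The source may hold more compounds than are shown below. What is called first, only, known or untested is meant among the compounds shown, and "the series" means these compounds.

Compound 1 `CCCCCC(=O)Nc1ccc(S(=O)(=O)Oc2ccccc2C(C)C)cc1` gives 6300 nM in a functional assay on HT-1080 cells (Homo sapiens) for antiproliferative activity, read by sulforhodamine B assay, with a stated time of 48 h (on this read-out higher numbers stand for weaker inhibition and lower numbers for stronger inhibition), the second highest of the three numbers shown; compound 2 `CCCCCC(=O)Nc1ccc(S(=O)(=O)Oc2ccccc2I)cc1` stands nearest with 9600 nM, and compound 3 `O=C(CCl)Nc1ccc(S(=O)(=O)Oc2ccccc2I)cc1` furthest with 600 nM. Compound 4 `CCNC(=O)Nc1ccc(S(=O)(=O)Oc2ccccc2C(C)C)cc1` differs from compound 1 by ethylamino in place of pentyl on a carbonyl carbon. Going by the values given here, no measured step changes the carbonyl substituent to an amino group. The step of a 1.5-fold higher number from compound 1 to compound 2 (0.18 log units; within the scatter) shows that a change on the aromatic carbon leaves the number nearly unchanged, whereas a 16-fold lower number from compound 2 to compound 3 (1.20 log units; beyond the scatter) shows that the chain on the carbonyl carbon is a place where a large step can occur. On these data alone, its direction for ethylamino is unknown, so a modest step is expected, a 1.6-fold higher number from compound 1 to compound 4 (0.20 log units; within the scatter), with wide uncertainty. Compound 4 is therefore estimated at 10000 nM, within 2500 nM to 40000 nM.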

Compound 4, half-maximal inhibitory concentration: 250 nM
For compound 4 the middle estimate is 40-fold (1.60 log units) above the measured one, outside the stated range (below it).
By their numbers in this assay, from the lowest: compound 4; then compound 3; then compounds 1 and 2 (each within the scatter of the next).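

In this assay, ethylamino in place of pentyl on a carbonyl carbon gives a 25-fold lower number from compound 1 to compound 4 (1.40 log units; beyond the scatter), the first large step shown for an amino group at this place. Going by these compounds alone, the only earlier large step here, a 16-fold lower number from compound 2 to compound 3 (1.20 log units; beyond the scatter), came with chloro in place of butyl, so two different replacements of a carbon chain on this carbonyl carbon now lower the number strongly. No measured evidence bears on why this happens. The compounds shown leave open whether the nitrogen or the shorter chain carries the step: a propyl group on the same carbonyl carbon would separate the two, and butylamino would extend the chain on the nitrogen.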